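A few compounds are considered here, and "the series" means these few. Any claim that something is new, unique, unknown or untested is made for them only; others in the source may bear on it.

Compound 1 `c1ccc(-c2ccc(OCc3nnc(-c4ccccc4)o3)cc2)cc1` and compound 2 `Clc1ccc(-c2nnc(COc3ccc(-c4ccccc4)cc3)o2)c(Cl)c1` share one core and differ in a single group. In a functional assay on the whole organism (strain Wistar) for inhibition, with Rattus norvegicus as the target, read by paw edema, with a stated time of 3 h, at a dose of 10 mg/kg by the oral route (a higher number here means more inhibition at the dose given (going by the name of the read-out), a lower number less inhibition), compound 1 gives 18.2%. In this assay compound 2 gives 56.1%, the highest of the two numbers; the step of a number 37.9 percentage points higher from compound 1 to compound 2 (beyond the scatter) shows that changing this group alone can shift the read-out a long way. Compound 3 `CCCCNc1nnc(COc2ccc(-c3ccccc3)cc2)o1` is not yet measured and differs from compound 2 by butylamino in place of 2,4-dichlorophenyl on an aromatic carbon. Among the compounds with values here, no measured step covers this change, so the direction is uncertain, and the one measured step only suggests that a wide move is possible. Compound 3 is therefore expected to give about 30%, between 10% and 55%. For compound 3 the expected step is a number 26.1 percentage points lower from compound 2 to compound 3 (beyond the scatter).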

Compound 3, a percentage reported as inhibition, in the whole organism at one dose (the size of the read-out at that dose, not a potency): 15.9%
Compound 3: the middle estimate sits 14.1 percentage points above what was measured, and the stated range covers the measured number.
By their numbers in this assay, from the lowest: compounds 3 and 1 (each within the scatter of the next); then compound 2.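

In this assay, replacing the ring with an open chain gives a number 40.2 percentage points lower from compound 2 to compound 3 (beyond the scatter) and so loses what 2,4-dichlorophenyl had gained. The comparison with plain phenyl gives a number 2.3 percentage points lower from compound 1 to compound 3 (within the scatter) and so shows no real difference: butylamino and phenyl sit level, and only 2,4-dichlorophenyl stands apart. Nothing available explains this result. Still open, as far as these compounds go, is whether a phenyl carrying a single chlorine, or one carrying two methyl groups, would match 2,4-dichlorophenyl. A cyclic amine such as morpholine could also show whether any non-aromatic group can do so here.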